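A few compounds are considered here, and "the series" means these few. Any claim that something is new, unique, unknown or untested is made for them only; others in the source may bear on it.

Compound 1 `O=C(NCc1ccccc1)N(Cc1ccccn1)n1cnnc1`: in a functional assay on MDA-MB-231 cells (Homo sapiens) for cytotoxicity, read by MTT assay, with a stated time of 48 h (on this read-out higher numbers stand for weaker inhibition and lower numbers for stronger inhibition), compound 1 gives only a limit, > 50000 nM.
Compound 2 `CCc1ccc(NC(=O)N(Cc2ccc(OC)c(OC)c2)n2cnnc2)cc1`: in this assay compound 2 gives only a limit, > 50000 nM.
Compound 3 `Cc1ccsc1CN(C(=O)Nc1ccc(Cl)c(C(F)(F)F)c1)n1cnnc1`: in this assay compound 3 gives 29600 nM.

Of the three measured compounds, two are reported as limits and only compound 3 as a number. Among the measured compounds shown here, compound 2 therefore stands at the limit of > 50000 nM in this assay, at which 2 of the 3 values shown sit, so nothing can be said of where it lies relative to compound 1, and compound 3 is the only one with a measured number at all.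

Compound 4 `COc1ccc(CN(C(=O)Nc2ccc(C)cc2)n2cnnc2)cc1OC` has not yet been measured in this assay. It differs from compound 2 in one place: hydrogen in place of methyl on a saturated chain carbon bound to an aromatic carbon. For the measured compounds named here, no step between two measured compounds is available to size this change, and the change itself is small, removing a single carbon from a chain. The expected step from compound 2 to compound 4 in this assay is therefore none beyond the scatter, estimated as a step that the limit leaves unreadable from compound 2 to compound 4. Compound 4 is expected to sit at or beyond the limit, with an estimated value of 60000 nM, ranging from 25000 nM to 150000 nM.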

Compound 4, half-maximal inhibitory concentration: > 50000 nM
Compound 4 was reported as a limit; the forecaster's own chance of this, stated with the estimate: 75%; the middle value lies beyond the limit too.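

In this assay compound 4 gives only a limit, > 50000 nM. Compound 2 is also reported only as a limit, so no step can be read between compound 2 and compound 4. The compounds shown leave open whether going from 4-ethylphenyl to 4-methylphenyl changes the cytotoxicity read-out at all.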